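A few compounds are considered here, and "the series" means these few. Any claim that something is new, unique, unknown or untested is made for them only; others in the source may bear on it.

Compound 2 `C=CCc1cccc(/C=N/NC(=O)Nc2ccc(Oc3ccnc4cc(OCCCN5CCCCC5)c(OC)cc34)c(F)c2)c1OC`: 250 nM in a functional assay on A549 cells (Homo sapiens) for cytotoxicity, read by MTT assay, with a stated time of 72 h; a higher number here means a weaker inhibitor, a lower number a stronger inhibitor
Compound 1 `COc1cc2c(Oc3ccc(NC(=O)N/N=C/c4ccc(C(F)(F)F)cc4)cc3F)ccnc2cc1OCCCN1CCCCC1`: 660 nM

Compound 2 gives the lowest of the two numbers in this assay; its nearest neighbour is compound 1, and a 2.6-fold lower number from compound 1 to compound 2 (0.42 log units; beyond the scatter). Compound 3 `COc1cc2c(Oc3ccc(NC(=O)N/N=C/c4cccs4)cc3F)ccnc2cc1OCCCN1CCCCC1` differs from compound 2 in one place: thiophen-2-yl in place of 3-allyl-2-methoxyphenyl on a carbon with a double bond to nitrogen. Within the data shown here, the only measured step that bears on this is the same kind of ring swap on that carbon, a 2.6-fold lower number from compound 1 to compound 2 (0.42 log units; beyond the scatter), which was modest, so a step of similar size is expected, with the direction uncertain. Compound 3 is therefore expected to give about 450 nM, within 150 nM to 1500 nM. The expected change is a 1.8-fold higher number from compound 2 to compound 3 (0.26 log units; within the scatter).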

Compound 3, half-maximal inhibitory concentration: 790 nM
The estimate for compound 3 lay 1.8-fold (0.24 log units) below the measured number; low and high end bracket the measured number.
By their numbers in this assay, from the lowest: compound 2; then compounds 1 and 3 (each within the scatter of the next).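

On a carbon with a double bond to nitrogen, the ring swap now shows that the outcome depends on which rings are compared. Replacing 3-allyl-2-methoxyphenyl with thiophen-2-yl gives a 3.2-fold higher number from compound 2 to compound 3 (0.50 log units; beyond the scatter) in this assay, whereas replacing 4-(trifluoromethyl)phenyl with thiophen-2-yl gives a 1.2-fold higher number from compound 1 to compound 3 (0.08 log units; within the scatter), so only compound 2 stands apart among these three compounds. No available evidence explains this difference. On these data alone, it remains open whether the allyl or the methoxy group alone would keep the lower number, and how a ring carrying an amine or a carboxylic acid would compare.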